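This account rests on a few compounds, and the source may have more. Where it says the series, first, only, none or still open, it means among the compounds named here.

Measured compounds:
Compound 1 `CC(C)[C@H](NC(=O)CNC(=O)c1cn(CC(=O)NOCc2ccccc2)c2ccccc12)C(=O)O`: in a functional assay on RAW264.7 cells (Mus musculus) for inhibition, read by microscopy and resazurin assay, with a stated time of 72 h (on this read-out lower numbers stand for stronger inhibition and higher numbers for weaker inhibition), compound 1 gives > 128000 nM, which is a limit of the assay and not a number.
Compound 2 `CC(C)C[C@H](NC(=O)CNC(=O)c1cn(CC(=O)NOCc2ccccc2)c2ccccc12)C(=O)O`: in this assay compound 2 gives > 128000 nM, again only a limit.
Compound 3 `C=CCONC(=O)Cn1ccc(C(=O)N[C@@H](C)C(=O)N[C@H](C(=O)O)C(C)C)c1`: in this assay compound 3 gives > 128000 nM, likewise a limit.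

Compound 1 and compound 2 share one core and differ by isobutyl in place of isopropyl on a saturated chain carbon bound to an amide-type nitrogen and a carbonyl carbon. The step that the two limits leave unreadable from compound 1 to compound 2 cannot be sized, since both values rest on (the limit of > 128000 nM in this assay, at which 3 of the 3 values shown sit). Compound 3 is built on another core; the difference between the two cores is not broken down here.

Compound 4 `C=CCONC(=O)Cn1ccc(C(=O)N[C@@H](C)C(=O)N[C@@H](CC(C)C)C(=O)O)c1` has not been measured in this assay. It differs from compound 3 by isobutyl in place of isopropyl on a saturated chain carbon bound to an amide-type nitrogen and a carbonyl carbon, the same change, at the same place, as from compound 1 to compound 2. Among the compounds with values here, that earlier step gave no readable size, and the only guidance is that all three measured values sit at the limit of > 128000 nM in this assay, at which 3 of the 3 values shown sit. The step expected in this assay is therefore a step that the limit leaves unreadable from compound 3 to compound 4, meaning no measurable gain. Compound 4 is estimated at 200000 nM, most likely reported as a limit again, because every measured value here stands at the limit of > 128000 nM in this assay, at which 3 of the 3 values shown sit.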

Compound 4, half-maximal inhibitory concentration: > 128000 nM
Compound 4 was reported as a limit (the forecaster's own chance of this, stated with the estimate: 90%); the middle value is on the limit's open side.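

No step can be read from compound 3 to compound 4, since in this assay both compounds stand only at a limit of the assay, as do the other values shown: the limit of > 128000 nM in this assay, at which 4 of the 4 values shown sit.

The compounds shown leave open what size isobutyl in place of isopropyl has on either core, and whether any of these structures gives a value that is not a limit in this assay.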